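Swapping fluoro for hydroxy on a cyclopentenone scaffold

The source may report more compounds than this note shows. Statements on the series, on what has been measured and on what is new or still open speak of the compounds shown alone.

Measured so far:
compound 1 `COc1ccc(C2=C(c3cc(OC)c(OC)c(OC)c3)C(=O)C(OC(C)=O)C2)cc1F` gives 16 ug/mL
compound 2 `COc1ccc(C2=C(c3cc(OC)c(OC)c(OC)c3)C(=O)C(O[SiH2]C(C)(C)C)C2)cc1OC(C)C` gives 6.3 ug/mL

In an ADME assay on DU-145 cells (Homo sapiens) for cytotoxicity, read by MTT assay, with a stated time of 72 h (a higher number here means a weaker inhibitor, a lower number a stronger inhibitor), compound 1 has the higher of the two numbers, with compound 2 lower by a gap beyond the scatter. Compound 3 `COc1ccc(C2=C(c3cc(OC)c(OC)c(OC)c3)C(=O)C(OC(C)=O)C2)cc1O` differs from compound 1 by a single change, (hydroxy in place of fluoro on an aromatic carbon), so that the aryl arm reads 3-hydroxy-4-methoxyphenyl instead of 3-fluoro-4-methoxyphenyl. Within the data shown here, no measured pair shows this exact exchange, so the step from compound 1 to compound 3 is an estimate, expected to be modest, with neither direction clearly favoured and likely within the scatter: a 1.3-fold lower number from compound 1 to compound 3 (0.12 log units; within the scatter). Compound 3 is therefore expected to give about 12 ug/mL, somewhere between 4 ug/mL and 40 ug/mL.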

Compound 3, half-maximal inhibitory concentration: > 100 ug/mL
Compound 3 ended at the assay's limit (the forecaster's own chance of this, stated with the estimate: 5%); middle value at least 8.3-fold (0.92 log units) away from the limit.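

In this assay, the exchange of fluoro for hydroxy on this aryl arm gives an at least 6.2-fold higher number from compound 1 to compound 3 (0.79 log units; beyond the scatter). So a swap of one heavy atom, ortho to a methoxy group, can separate a measurable compound from one that reaches the top of the assay's range. The full size of the step stays unknown, since compound 3 is recorded as a limit and not as a number: the limit of > 100 ug/mL in this assay, at which 1 of the 3 values shown sits.

The compounds shown leave open whether an amine or a chlorine at this place would read closer to compound 1 or to compound 3. They also leave open whether hydroxy would have the same effect with the silicon-bearing side group of compound 2.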